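Solubility of a fourth analogue in the shared series

The source may hold more compounds than are shown below. What is called first, only, known or untested is meant among the compounds shown, and "the series" means these compounds.

Of the compounds shown here, three have been measured in a physicochemical assay for solubility, read by spectrophotometry, measured as kinetic solubility, at pH 8, tested at 500 uM; on this read-out lower numbers stand for lower solubility and higher numbers for higher solubility. Compound 1 `CNS(=O)(=O)c1ccccc1Nc1cc(-c2ccc3ccn(C)c3c2)c2nccnc2c1` gives 2 ug/mL. Compound 2 `Cn1ccc2ccc(-c3cc(Nc4ccccc4S(=O)(=O)Nc4cncnc4)cc4nccnc34)cc21` gives 254 ug/mL, and compound 3 `Cn1ccc2ccc(-c3cc(Nc4cnccc4C(=O)NCc4cncnc4)cc4nccnc34)cc21` gives 233 ug/mL. Compound 3 therefore stands second highest of the three numbers; its nearest neighbour is compound 2, within the scatter, and its furthest is compound 1, far beyond it. Within the data shown here, the single measured step, a 130-fold higher number from compound 1 to compound 2 (2.10 log units; beyond the scatter), concerns a sulfonamide nitrogen.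

Compound 4 `CC(=O)N1CC(NC(=O)c2ccncc2Nc2cc(-c3ccc4ccn(C)c4c3)c3nccnc3c2)C1` differs from compound 3 in one place: 1-acetylazetidin-3-yl in place of (pyrimidin-5-yl)methyl on an amide-type nitrogen. Among the measured compounds shown here, no measured step touches an amide-type nitrogen, so none bears directly on this change; the only comparable evidence is that compound 2 and compound 3 both give high numbers while carrying a pyrimidin-5-yl group. Compound 3 already lies close to the highest value seen, and a drop beyond the scatter is not indicated by anything measured. The step from compound 3 to compound 4 is therefore expected to be small, a 1.2-fold lower number from compound 3 to compound 4 (0.09 log units; within the scatter). In this assay compound 4 is estimated at 190 ug/mL, with a range from 70 ug/mL to 240 ug/mL.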

Compound 4, solubility: 244 ug/mL
For compound 4 the middle estimate is 1.3-fold (0.11 log units) below the measured one, and the stated range ends below it.
By their numbers in this assay, from the lowest: compound 1; then compounds 3, 4 and 2 (each within the scatter of the next).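

In this assay, among these compounds, the first measured step on this amide-type nitrogen is a 1.0-fold higher number from compound 3 to compound 4 (0.02 log units; within the scatter), with 1-acetylazetidin-3-yl in place of (pyrimidin-5-yl)methyl. The two groups have the same number of heavy atoms but different rings, one six-membered and aromatic, the other four-membered and non-aromatic, and their numbers cannot be told apart, so a pyrimidin-5-yl group is not needed at this position for a number of this size. Nothing at hand explains why these two groups read alike.

Going by these compounds, it remains open whether a plain methyl, a carboxylic acid or a piperidine ring on the same amide-type nitrogen would read alike. On these data alone, it is equally open whether 1-acetylazetidin-3-yl would give a similar number on the sulfonamide nitrogen of compound 2.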